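A Thiophene for a Pyridine on the Amide Side

The source may hold more compounds than are shown below. What is called first, only, known or untested is meant among the compounds shown, and "the series" means these compounds.

Compound 1 `CS(=O)(=O)NCCCN(c1nc(C(=O)NCc2ccc(F)cc2)c(O)c2ncccc12)S(C)(=O)=O`: > 20000 nM
Compound 2 `N[C@H]1CC[C@H](Nc2c(C(=O)NCc3ccccn3)nc(Br)c3cccnc23)CC1`: 4000 nM
Compound 3 `O=C(NCc1ccc(F)cc1)c1nc(NCCO)c2cccnc2c1O`: > 20000 nM

In a functional assay on MDA-MB-435 cells (Homo sapiens) for cytotoxicity, read by MTT assay, with a stated time of 72 h (a lower number here means a stronger inhibitor, a higher number a weaker inhibitor), compound 2 gives 4000 nM. Compound 1 reaches only a limit, > 20000 nM. Compound 3 likewise reports only a limit, > 20000 nM. Going by the values given here, compound 2 thus holds the only numeric value here, while the other two sit at the limit of > 20000 nM in this assay, at which 2 of the 3 values shown sit. Compound 4 `N[C@H]1CC[C@H](Nc2c(C(=O)NCc3cccs3)nc(Br)c3cccnc23)CC1` differs from compound 2 in one place: thiophen-2-yl in place of pyridin-2-yl on a saturated chain carbon bound to an amide-type nitrogen. Among the compounds with values here, no step between measured compounds exists to calibrate this exchange, so the step is expected to be small, no change at the digits printed from compound 2 to compound 4 (within the scatter), staying within the usual scatter in this assay. Compound 4 is therefore estimated at 4000 nM, with a range from 1500 nM to 12000 nM.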

Compound 4, half-maximal inhibitory concentration: 4100 nM
For compound 4 the middle estimate is 1.0-fold (0.01 log units) below the measured one; the measured number falls inside the stated range.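

Going by these compounds alone, compounds 1 and 3 differ from compound 2 in more than one place, so only this pair isolates the group on the saturated chain carbon bound to an amide-type nitrogen. In this assay, thiophen-2-yl in place of pyridin-2-yl gives a 1.0-fold higher number from compound 2 to compound 4 (0.01 log units; within the scatter), so at this place the ring nitrogen of pyridin-2-yl can be exchanged for a five-membered ring with sulfur without a step beyond the scatter. Nothing shown accounts for why the two groups read alike.

The compounds shown leave open how a phenyl or furan-2-yl ring, or a longer chain to the amide nitrogen, would read here. They also leave open whether this exchange would read alike on another core.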